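Methyl for methoxy on the aryl ring of compound 1

The source may report more compounds than this note shows. Statements on the series, on what has been measured and on what is new or still open speak of the compounds shown alone.

Three compounds share one core. Compound 1 `COc1ccc(-c2cc(COc3ccccc3-c3nc4ccccc4s3)on2)cc1` gives 20700 nM in a functional assay on COLO 205 cells (Homo sapiens) for cytotoxicity, read by MTT assay, with a stated time of 24 h; a higher number here means a weaker inhibitor, a lower number a stronger inhibitor. Compound 2 `c1ccc(-n2cc(COc3ccccc3-c3nc4ccccc4s3)nn2)cc1` gives 16600 nM, and compound 3 `Fc1ccc(-n2cc(COc3ccccc3-c3nc4ccccc4s3)nn2)cc1Cl` gives 14400 nM; all three numbers lie within the usual scatter of one another, so compound 1 stands together with them rather than apart. Compound 4 `Cc1ccc(-c2cc(COc3ccccc3-c3nc4ccccc4s3)on2)cc1` differs from compound 1 by methyl in place of methoxy on an aromatic carbon. Going by the values given here, the only measured step, a 1.2-fold lower number from compound 2 to compound 3 (0.06 log units; within the scatter), concerns a change at a different position of a different aromatic ring and stayed within the scatter; it offers little guidance on the present change. A step from compound 1 to compound 4 no larger than the scatter is therefore expected, in no particular direction: compound 4 is estimated at 20000 nM, with a range from 9000 nM to 45000 nM, meaning a 1.0-fold lower number from compound 1 to compound 4 (0.01 log units; within the scatter).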

Compound 4, half-maximal inhibitory concentration: 14200 nM
Compound 4: middle estimate off by 1.4-fold (0.15 log units), on the high side, within the range that was stated.
By their numbers in this assay, from the lowest: compounds 4, 3, 2 and 1 (each within the scatter of the next).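

In this assay the exchange of 4-methoxyphenyl for 4-methylphenyl gives a 1.5-fold lower number from compound 1 to compound 4 (0.16 log units; within the scatter), so removing the oxygen of the methoxy group from this aromatic carbon leaves the number within the scatter. This is the only step shown at this position, and it joins the step at the other aryl ring in staying within the scatter. Nothing available bears on the reason for this result.

As far as these compounds go, whether an amine, a carboxylic acid or a longer chain such as butoxy on this aromatic carbon would move the number beyond the scatter remains open.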